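Methoxy in place of nitro on the pendant phenyl ring

The source may hold more compounds than are shown below. What is called first, only, known or untested is meant among the compounds shown, and "the series" means these compounds.

Measured compounds:
compound 1 `O=C(Nc1ccc(Oc2ccnc3[nH]ccc23)c(F)c1)c1nccc(-c2cccc(Cl)c2)n1` — 1580 nM
compound 2 `O=C(Nc1ccc(Oc2ccnc3[nH]ccc23)c(F)c1)c1nccc(-c2ccc([N+](=O)[O-])cc2)n1` — "not active" (no number reported)

Of the compounds shown here, two sharing one core have been measured in a functional assay on MCF7 cells (Homo sapiens) for cytotoxicity, read by MTT assay, with a stated time of 72 h; a lower number here means a stronger inhibitor, a higher number a weaker inhibitor. Compound 1 `O=C(Nc1ccc(Oc2ccnc3[nH]ccc23)c(F)c1)c1nccc(-c2cccc(Cl)c2)n1` carries a 3-chlorophenyl group and in this assay compound 1 gives 1580 nM. Compound 2 `O=C(Nc1ccc(Oc2ccnc3[nH]ccc23)c(F)c1)c1nccc(-c2ccc([N+](=O)[O-])cc2)n1` carries a 4-nitrophenyl group instead, and in this assay compound 2 gives "not active" (no number reported), so compound 2 stands with no single number on the scale. No number exists for compound 2. The two results therefore cannot be set against each other as a step of any size; they only show that compound 1 has a measured value where compound 2 has none.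

Compound 3 `COc1ccc(-c2ccnc(C(=O)Nc3ccc(Oc4ccnc5[nH]ccc45)c(F)c3)n2)cc1` is not yet measured. It differs from compound 2 in one place: methoxy in place of nitro on an aromatic carbon. For the measured compounds named here, with no measured step for this change, no direction can be read from the data; a return to a measurable number, on the order of compound 1, is taken as the likelier outcome. Compound 3 is expected to give 2500 nM in this assay, within a range of 600 nM to 12000 nM.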

Compound 3, half-maximal inhibitory concentration: 8960 nM
For compound 3 the middle estimate is 3.6-fold (0.55 log units) below the measured one; the range from low to high includes it.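

With methoxy in place of nitro, compound 3 has a number in this assay, so a group at this place on the pendant phenyl ring, para to a large group, can go with measurable cytotoxicity; the change from compound 2 still cannot be read as a step of any size, as compound 2 has no number on the scale. For the compounds shown here, the one step that can be read is a 5.7-fold higher number from compound 1 to compound 3 (0.75 log units; beyond the scatter), a modest change that makes compound 3 the weaker inhibitor of the pair, so 4-methoxyphenyl does not match 3-chlorophenyl here. No measurement at hand accounts for either result.

Compound 1 and compound 3 differ in both the group and the place it occupies on the phenyl ring, so the compounds shown cannot separate these two changes, and a 3-methoxyphenyl or a 4-chlorophenyl group would be needed to tell them apart. Also open, as far as these compounds go, is how an amine, a carboxylic acid or a longer alkoxy chain at this same place would compare with methoxy.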